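A few compounds are considered here, and "the series" means these few. Any claim that something is new, unique, unknown or untested is made for them only; others in the source may bear on it.

Working notes on the series. Among the compounds with values here, compound 3 `CN(C)/C=C/N1CCN(CC(=O)Nc2ccc(-c3nc(-c4ccccc4)c(-c4ccccc4)n3C)cc2)CC1` gives 45.4% in a functional assay on HT-29 cells (Homo sapiens) for cytotoxicity, read by MTT assay, with a stated time of 24 h, tested at 80 ug/mL (on this read-out higher numbers stand for a stronger effect at the one concentration tested and lower numbers for a weaker effect), and stands lowest of the three numbers measured so far; its nearest neighbour is compound 2 `CN1CCN(CC(=O)Nc2ccc(-c3nc(-c4ccccc4)c(-c4ccccc4)n3C)cc2)CC1` at 53.1%, which lies within the scatter of it, and its furthest is compound 1 `Cn1c(-c2ccc(NC(=O)CSc3nc4cc(Cl)ccc4o3)cc2)nc(-c2ccccc2)c1-c1ccccc1` at 79.6%, which lies beyond the scatter. Compound 4 `Cn1c(-c2ccc(NC(=O)CN3CCN(Cc4ccccc4)CC3)cc2)nc(-c2ccccc2)c1-c1ccccc1` is not yet measured in this assay. It differs from compound 3 as follows: benzyl in place of 2-(dimethylamino)ethenyl on an amine nitrogen in a ring. Of the measured steps, a number 26.5 percentage points lower from compound 1 to compound 2 (beyond the scatter) and a number 34.2 percentage points lower from compound 1 to compound 3 (beyond the scatter) each exchange the whole group on the saturated chain carbon bound to the carbonyl carbon, so they bear only loosely on the present change. The step that touches the same amine nitrogen in the ring, a number 7.7 percentage points lower from compound 2 to compound 3 (within the scatter), was within the scatter, which suggests that substituents at this nitrogen move this assay little. A change of no size beyond the scatter is therefore expected, in no firm direction, with the estimated step being a number 2.6 percentage points higher from compound 3 to compound 4 (within the scatter). Compound 4 is thus estimated at 48%, with a range from 34% to 64%.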

Compound 4, a percentage reported as activity, at one concentration (the size of the read-out at that concentration, not a potency): 54.5%
Compound 4: middle estimate off by 6.5 percentage points, on the low side, and the stated range covers the measured number.
By their numbers in this assay, from the lowest: compounds 3, 2 and 4 (each within the scatter of the next); then compound 1.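

At the amine nitrogen in the ring, benzyl in place of 2-(dimethylamino)ethenyl gives a number 9.1 percentage points higher from compound 3 to compound 4 (within the scatter), and phenyl in place of hydrogen on the saturated chain carbon bound to that nitrogen gives a number 1.4 percentage points higher from compound 2 to compound 4 (within the scatter). With methyl, 2-(dimethylamino)ethenyl and benzyl now compared at this nitrogen, all three steps between them in this assay lie within the scatter, so even the entry of a six-membered aromatic ring of carbon only does not separate compound 4 from compound 2 or compound 3. No measurement gives a reason for this result.

As far as these compounds go, it remains open whether a carboxylic acid on a chain at this nitrogen, or an acetyl group, would also stay within the scatter. The compounds shown also leave open whether a benzyl carrying chlorine behaves like the plain benzyl, and whether the picture holds at other concentrations.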